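Swapping the thiazole for a pyrazole on the piperazine methylene

A few compounds are considered here, and "the series" means these few. Any claim that something is new, unique, unknown or untested is made for them only; others in the source may bear on it.

Measured compounds:
- Compound 1, `Cc1nc(CN2CCN(c3cccc4[nH]c(-c5ccc(C(C)(C)C)cc5)nc34)CC2)c[nH]1`, gives 28 nM in an assay on isolated protein for displacement of a labelled ligand from Gonadotropin-releasing hormone receptor (Rattus norvegicus); a lower number here means a stronger inhibitor, a higher number a weaker inhibitor.
- Compound 2, `CCc1nc(C)c(CN2CCN(c3cccc4[nH]c(-c5ccc(C(C)(C)C)cc5)nc34)CC2)s1`, gives 120 nM in this assay.

Compound 2 stands at the higher of the two numbers, with compound 1 the nearer and only neighbour, separated by the step of a 4.3-fold higher number from compound 1 to compound 2 (0.63 log units; beyond the scatter). Compound 3, `CCc1cc(CN2CCN(c3cccc4[nH]c(-c5ccc(C(C)(C)C)cc5)nc34)CC2)n(C)n1`, differs from compound 2 only in the heteroaryl group: 3-ethyl-1-methyl-1H-pyrazol-5-yl in place of 2-ethyl-4-methyl-1,3-thiazol-5-yl on a saturated chain carbon bound to an amine nitrogen in a ring. Within the data shown here, the one measured step, the change from the imidazole of compound 1 to the thiazole of compound 2, was modest in size and bears on the present change only loosely, since compound 3 resembles compound 2 in carrying no hydrogen-bond donor on the ring. Nothing in hand argues for a large shift in either direction. The expected step is therefore a 1.2-fold lower number from compound 2 to compound 3 (0.08 log units; within the scatter), within or just at the edge of the scatter. Compound 3 is estimated at 100 nM, with a range from 35 nM to 300 nM.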

Compound 3, half-maximal inhibitory concentration: 250 nM
Beside the measured number, compound 3's estimate is 2.5-fold (0.40 log units) below it; low and high end bracket the measured number.
By their numbers in this assay, from the lowest: compound 1; then compound 2; then compound 3.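

Placed on a saturated chain carbon bound to an amine nitrogen in a ring, 3-ethyl-1-methyl-1H-pyrazol-5-yl and 2-ethyl-4-methyl-1,3-thiazol-5-yl match in heavy atoms, hydrogen-bond donors and hydrogen-bond acceptors, yet they are not interchangeable in this assay (the exchange gives a 2.1-fold higher number from compound 2 to compound 3 (0.32 log units; beyond the scatter)). Both groups without a hydrogen-bond donor now give higher numbers than the 2-methyl-1H-imidazol-4-yl of compound 1, the wider gap being (an 8.9-fold higher number from compound 1 to compound 3 (0.95 log units; beyond the scatter)), and none of the three compounds goes against this ordering. Nothing available accounts for these differences.

From the compounds shown here alone, it remains open whether a propyl chain in place of the methyl on the imidazole would keep the number of compound 1. A pyridyl or plain phenyl group at this place could fall closer to either the imidazole or the other two groups.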